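The source may report more compounds than this note shows. Statements on the series, on what has been measured and on what is new or still open speak of the compounds shown alone.

Measured compounds:
- compound 1, `O=S(=O)(NCCCNCc1ccc(Cl)c(Cl)c1)c1cc(C(F)(F)F)cc(C(F)(F)F)c1`, 1400 nM in a functional assay on BXPC-3 cells (Homo sapiens) for inhibition, read by MTT assay, with a stated time of 72 h; on this read-out higher numbers stand for weaker inhibition of growth and lower numbers for stronger inhibition of growth
- compound 2, `O=S(=O)(NCCCNCc1ccc(C(F)(F)F)cc1)c1cc(C(F)(F)F)cc(C(F)(F)F)c1`, 1700 nM in this assay
- compound 3, `O=S(=O)(NCCCNCc1ccc(Cl)cc1)c1cc(C(F)(F)F)cc(C(F)(F)F)c1`, 1600 nM in this assay

Compound 3 sits second highest of the three numbers in this assay, and its neighbours lie close on either side: a 1.1-fold lower number from compound 2 to compound 3 (0.03 log units; within the scatter) and a 1.1-fold higher number from compound 1 to compound 3 (0.06 log units; within the scatter). The three measured compounds share the same core and differ only in the benzyl group on the amine, yet a 1.2-fold higher number from compound 1 to compound 2 (0.08 log units; within the scatter) shows that even a swap of the whole aryl group leaves the read-out essentially unchanged.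

Compound 4, `COc1ccccc1CNCCCNS(=O)(=O)c1cc(C(F)(F)F)cc(C(F)(F)F)c1`, continues this series with a further change of that group: 2-methoxyphenyl in place of 4-chlorophenyl on a saturated chain carbon bound to an amine nitrogen. Going by the values given here, no measured step exchanges a chlorophenyl for a methoxyphenyl, nor moves a substituent to a different ring position, so the nearest guidance is the general insensitivity seen across compounds 1, 2 and 3. On that basis compound 4 is expected to stay near compound 3, with a 1.3-fold higher number from compound 3 to compound 4 (0.10 log units; within the scatter) as the estimated step and no direction asserted beyond the scatter. The estimate for compound 4 in this assay is 2000 nM, within 800 nM to 5000 nM.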

Compound 4, concentration for 50% growth inhibition: 1700 nM
For compound 4 the middle estimate is 1.2-fold (0.07 log units) above the measured one; the measured number falls inside the stated range.
By their numbers in this assay, from the lowest: compounds 1, 3, 2 and 4 (each within the scatter of the next).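

In this assay, the position on a saturated chain carbon bound to an amine nitrogen also accepts a substituent of another kind: 2-methoxyphenyl, with one hydrogen-bond acceptor where 4-chlorophenyl has none, gives a 1.1-fold higher number from compound 3 to compound 4 (0.03 log units; within the scatter). The comparisons with the other aryl groups read the same way, with no change at the digits printed from compound 2 to compound 4 (within the scatter) and a 1.2-fold higher number from compound 1 to compound 4 (0.08 log units; within the scatter), so the flat response seen with the chloro and trifluoromethyl groups now extends to a methoxy group, and none of the four compounds goes against it. Nothing available explains why this position responds so little.

As far as these compounds go, it remains open whether a carboxylic acid or an amine on this aryl ring would shift the number beyond the scatter. Also open, from the compounds shown here alone, is whether any change outside this position, such as a longer chain in the shared core, would do so.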